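Diisobutylamino in Place of Cyclohexylamino on the Urea Core

The source may hold more compounds than are shown below. What is called first, only, known or untested is meant among the compounds shown, and "the series" means these compounds.

The three measured compounds share one core and differ only in the amine on its central aromatic ring. In an assay on HeLa cells for inhibition of Indoleamine 2,3-dioxygenase 1 (Homo sapiens), with stated times of 1 h and 18 h (a higher number here means a weaker inhibitor, a lower number a stronger inhibitor), compound 2 `Cc1ccc(NC(=O)Nc2cc(-c3ccccc3C(=O)O)ccc2NC2CCCCC2)cc1` gives 504 nM. Compound 3 `CCN(c1ccc(-c2ccccc2C(=O)O)cc1NC(=O)Nc1ccc(C)cc1)C1CCCC1` gives 23 nM in this assay. Compound 1 `Cc1ccc(NC(=O)Nc2cc(-c3ccccc3C(=O)O)ccc2N(C)c2ccccc2C(C)(C)C)cc1` yields only a limit in this assay, namely > 1000 nM (the limit of > 1000 nM in this assay, at which 1 of the 3 values shown sits). Of the two real numbers, compound 2 therefore stands highest, and its nearest neighbour is reached by the step of a 22-fold lower number from compound 2 to compound 3 (1.34 log units; beyond the scatter). The steps of an at least 1.9-fold lower number from compound 1 to compound 2 (0.29 log units; that floor lies within the scatter) and an at least 43-fold lower number from compound 1 to compound 3 (1.63 log units; beyond the scatter) start from a limit and so set floors only.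

Compound 4 `Cc1ccc(NC(=O)Nc2cc(-c3ccccc3C(=O)O)ccc2N(CC(C)C)CC(C)C)cc1` is not yet measured. Its change from compound 2 is diisobutylamino in place of cyclohexylamino on an aromatic carbon. The step that bears on it most directly is a 22-fold lower number from compound 2 to compound 3 (1.34 log units; beyond the scatter), where a secondary amine carrying a ring gave way to a tertiary amine carrying an ethyl group and a ring, with a large gain. Among the compounds with values here, the entering diisobutylamino group is likewise tertiary but carries no ring, and no measured compound shows such a group, so the account expects a gain of smaller size, a 5.6-fold lower number from compound 2 to compound 4 (0.75 log units; beyond the scatter). Compound 4 is estimated at 90 nM, within the range 20 nM to 400 nM.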

Compound 4, half-maximal inhibitory concentration: 13 nM
Compound 4: the middle estimate sits 6.9-fold (0.84 log units) above what was measured; the whole stated range lies above it.
By their numbers in this assay, from the lowest: compounds 4 and 3 (each within the scatter of the next); then compound 2. At a limit, above all of these: compound 1.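

In this assay, the swap on this aromatic carbon, para to a 2-carboxyphenyl group, gives a 39-fold lower number from compound 2 to compound 4 (1.59 log units; beyond the scatter), so a large gain over the secondary cyclohexylamino group is now seen with a tertiary amine that carries no ring at all, where the earlier compounds had shown it only with a ring still on the nitrogen. The ring on that nitrogen is therefore not required for this level of inhibition, and a 1.8-fold lower number from compound 3 to compound 4 (0.25 log units; within the scatter) means that the open-chain diisobutylamino group and the cyclopentyl(ethyl)amino group cannot be told apart in this measurement. The remaining step, an at least 76-fold lower number from compound 1 to compound 4 (1.88 log units; beyond the scatter), sets a floor only, its starting value being a limit: the limit of > 1000 nM in this assay, at which 1 of the 4 values shown sits.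

Going by these compounds, whether the gain belongs to the loss of the amine hydrogen or to the size and shape of the groups on the nitrogen stays open, and a cyclohexyl(methyl)amino group, which keeps the six-membered ring on a tertiary nitrogen, would separate the two. How far the open-chain groups can shrink is also unsettled, as a diethylamino group on the same carbon would show.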